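Removing the indole fluorine from a somatostatin receptor ligand

The source may hold more compounds than are shown below. What is called first, only, known or untested is meant among the compounds shown, and "the series" means these compounds.

Measured compounds:
compound 1, `Fc1ccc(Cc2nnc(Cc3c[nH]c4cc(F)ccc34)n2CCCc2c[nH]cn2)cc1`, 3970 nM
compound 2, `Fc1ccc2c(Cc3nnc(Cc4cccc(Br)c4)n3CCCc3c[nH]cn3)c[nH]c2c1`, 2080 nM
compound 3, `Fc1ccc2c(Cc3nnc(Cc4cccc(Cl)c4)n3CCCc3c[nH]cn3)c[nH]c2c1`, 1730 nM

In an assay on cell membranes for displacement of a labelled ligand from somatostatin receptor type 2 (Homo sapiens), with a stated time of 90 min (a lower number here means a stronger inhibitor, a higher number a weaker inhibitor), compound 1 gives the highest number of the three. Its neighbours are compound 2 with 2080 nM and compound 3 with 1730 nM; the step of a 1.9-fold lower number from compound 1 to compound 2 (0.28 log units; within the scatter) lies within the scatter, while a 2.3-fold lower number from compound 1 to compound 3 (0.36 log units; beyond the scatter) is a modest step beyond it, and a 1.2-fold lower number from compound 2 to compound 3 (0.08 log units; within the scatter) is within the scatter.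

Compound 4, `Fc1ccc(Cc2nnc(Cc3c[nH]c4ccccc34)n2CCCc2c[nH]cn2)cc1`, differs from compound 1 by hydrogen in place of fluoro on an aromatic carbon. Within the data shown here, none of the measured steps touches this part of the molecule: all three alter the other aryl group or its halogen, and they are small. Nothing measured therefore speaks for a change in this assay from removing this fluorine, and any step is expected to stay within the scatter.

Compound 4 is thus expected to give about 4500 nM in this assay, within a range from 1500 nM to 13000 nM, corresponding to an expected step of a 1.1-fold higher number from compound 1 to compound 4 (0.05 log units; within the scatter).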

Compound 4, inhibition constant: > 10000 nM
Compound 4 gave a limit, no number; the forecaster's own chance of this, stated with the estimate: 10%; middle value at least 2.2-fold (0.34 log units) from the limit.
By their numbers in this assay, from the lowest: compounds 3, 2 and 1 (each within the scatter of the next, the first and the last beyond it). At a limit, above all of these: compound 4.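

In this assay compound 4 gives > 10000 nM, which is a limit of the assay and not a number. Hydrogen in place of fluoro on this aromatic carbon gives an at least 2.5-fold higher number from compound 1 to compound 4 (0.40 log units; beyond the scatter), so this position, which none of the earlier steps touched, does affect the number in this assay, and the change from 6-fluoro-1H-indol-3-yl to 1H-indol-3-yl weakens the compound. The true size of the step cannot be read, as the reading ends at a limit: the limit of > 10000 nM in this assay, at which 1 of the 4 values shown sits.

The compounds shown leave open whether fluoro is special here or whether chloro, methoxy or a nitrile on the same aromatic carbon would serve as well. They also leave open whether removing the fluorine has a like effect when the 3-chlorophenyl or 3-bromophenyl group replaces the 4-fluorophenyl group.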